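Swapping an aromatic ring on a shared pyrimidinone-like core

This account rests on a few compounds, and the source may have more. Where it says the series, first, only, none or still open, it means among the compounds named here.

Of the compounds shown here, three built on the same core have been tested. Compound 1 `CCOC(=O)c1cnn(-c2nc(-c3ccc(OC)cc3)c(C#N)c(=O)n2C)c1N` gives 79 ug/mL in a functional assay, with a stated time of 150 min; a lower number here means a stronger inhibitor, a higher number a weaker inhibitor. Compound 2 `CSc1nc(-c2ccco2)c(C#N)c(=O)n1C` gives 108 ug/mL in this assay, and compound 3 `COc1cccc(-c2nc(NN)n(C)c(=O)c2C#N)c1OC` gives 54 ug/mL. The number for compound 1 lies close to those of compound 2 and compound 3, within the scatter of each, so the three cannot be ranked.

Compound 4 `CCOC(=O)c1cnn(-c2nc(-c3ccco3)c(C#N)c(=O)n2C)c1N` differs from compound 1 in one place: furan-2-yl in place of 4-methoxyphenyl on an aromatic carbon. For the measured compounds named here, no matched pair among the measured compounds isolates this change, and the three numbers so far barely move, so compound 1 to compound 4 is expected to show no step beyond the scatter, a 1.1-fold higher number from compound 1 to compound 4 (0.03 log units; within the scatter). Compound 4 is thus estimated at 85 ug/mL, with a range from 40 ug/mL to 180 ug/mL.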

Compound 4, half-maximal inhibitory concentration: 108 ug/mL
Estimate against measurement, compound 4: 1.3-fold (0.10 log units) below; the range from low to high includes it.
By their numbers in this assay, from the lowest: compounds 3, 1, 2 and 4 (each within the scatter of the next).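

In this assay, the swap gives a 1.4-fold higher number from compound 1 to compound 4 (0.14 log units; within the scatter). For the compounds shown here, this is the first matched pair at this position next to the ring nitrogen, and it shows that a five-membered furan-2-yl ring can stand in place of the six-membered 4-methoxyphenyl ring with no step beyond the scatter. No measured evidence here bears on this result.

Still open, as far as these compounds go, is whether a group of another kind on this carbon, such as an amine or a carboxylic acid, would give a step beyond the scatter. From the compounds shown here alone, whether the same swap behaves alike with another group in place of the ester-bearing ring of compound 1 also stays open.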